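Three ureas at the ceiling, and a trifluoromethyl question

The compounds below may be only part of what the source reports. "The series", "measured", "known", "first", "only" and "open" are said of these compounds alone.

Three small ureas have been tested in an ADME assay on the whole organism with Oryza sativa as the target, tested at 0.1 uM; on this read-out lower numbers stand for a stronger effect and higher numbers for a weaker effect at the one concentration tested. Compound 1 `Cc1ccc(NC(=O)N[C@H](C)c2ccccc2)cc1` gives 100%. Compound 2 `Cc1ccc(NC(=O)N[C@@H](C)c2ccccc2)cc1` gives 100%, and compound 3 `CCc1cccc(NC(=O)N[C@@H](C)c2ccccc2)c1` gives 100%. Compound 2 therefore stands level with both of its neighbours; the values sit together and none of the three can be called stronger or weaker than another.

Among the compounds with values here, the one measured step between neighbours that differ in a single place runs from compound 1 to compound 2: no change at the digits printed from compound 1 to compound 2 (within the scatter). This pair is special in that (the fact that compounds 1 and 2 differ only in the configuration as drawn), so the step tells only that turning the stereocentre leaves this read-out untouched.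

The next compound, compound 4 `C[C@H](NC(=O)Nc1ccc(C(F)(F)F)cc1)c1ccccc1`, is reached from compound 2 by a change of a different kind: trifluoromethyl in place of methyl on an aromatic carbon. Within the data shown here, no measured step concerns a swap of this sort, so the only guidance is that every compound so far sits at the same top value. On that basis, no step beyond the scatter is expected; the expected step is no change at the digits printed from compound 2 to compound 4 (within the scatter). For compound 4 in this assay the estimate is 100%, within a range from 85% to 100%.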

Compound 4, a percentage reported as activity, at one concentration (the size of the read-out at that concentration, not a potency): 94%
The estimate for compound 4 lay 6 percentage points above the measured number, within the range that was stated.
By their numbers in this assay, from the lowest: compounds 4, 1, 2 and 3 (each within the scatter of the next).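

Trifluoromethyl in place of methyl on an aromatic carbon, para to a large group, gives a number 6 percentage points lower from compound 2 to compound 4 (within the scatter) in this assay. Within the data shown here, the earlier step only turned a stereocentre, so this is the first measured step that replaces a group on the aromatic ring, and it shows that 4 heavy atoms, three of them fluorine, can stand where methyl's 1 heavy atom stood without a step beyond the usual scatter. The information at hand says nothing about why this swap reads as it does.

The compounds shown leave open whether any group at this place can bring the read-out clearly away from the top of the range, and a carboxylic acid, an amine or a longer chain such as butyl on the same aromatic carbon would put that to the test. They also leave open whether turning the stereocentre would still leave the read-out untouched with trifluoromethyl on the ring, as it did in the pair carrying methyl.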